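Aryl ether change from compound 3 to compound 4

The source may report more compounds than this note shows. Statements on the series, on what has been measured and on what is new or still open speak of the compounds shown alone.

In an ADME assay on PBMC cells (Homo sapiens) for cytotoxicity (a higher number here means that more compound is tolerated, a lower number that less compound is tolerated), compound 3 `CC(CCNC(=O)c1c(Cl)cncc1Cl)N1CCC(C(Oc2ccccn2)c2ccc(C(F)(F)F)cc2)CC1` gives 34100 nM. It sits level with compound 1 `Cc1ccnc(OC(c2ccc(C(F)(F)F)cc2)C2CCN(C(C)CCNC(=O)c3c(Cl)cncc3Cl)CC2)c1` at 33600 nM, while compound 2 `CC(CCNC(=O)c1c(Cl)cncc1Cl)N1CCC(C(Oc2ccccc2)c2ccc(C(F)(F)F)cc2)CC1` lies lower at 6800 nM.

Compound 4 `CC(CCNC(=O)c1c(Cl)cncc1Cl)N1CCC(C(Oc2cccc(Cl)c2)c2ccc(C(F)(F)F)cc2)CC1` differs from compound 3 as follows: 3-chlorophenyl in place of pyridin-2-yl on an oxygen on a saturated carbon. Its ring on the oxygen is carbon only, as in compound 2. The closest guides are therefore a 5.0-fold higher number from compound 2 to compound 3 (0.70 log units; beyond the scatter), read in reverse, and a 4.9-fold lower number from compound 1 to compound 2 (0.69 log units; beyond the scatter). Removing the methyl, a 1.0-fold higher number from compound 1 to compound 3 (0.01 log units; within the scatter), changes nothing beyond the scatter. Among the compounds with values here, no measured compound carries the chlorine, so its contribution is unknown.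

A lower number is expected, with an estimated 5.2-fold lower number from compound 3 to compound 4 (0.72 log units; beyond the scatter). For compound 4 the estimate is 6500 nM, with an expected range of 2500 nM to 16000 nM.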

Compound 4, half-maximal cytotoxic concentration: 8100 nM
For compound 4 the middle estimate is 1.2-fold (0.10 log units) below the measured one; the range from low to high includes it.
By their numbers in this assay, from the lowest: compounds 2 and 4 (each within the scatter of the next); then compounds 1 and 3 (each within the scatter of the next).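

In this assay the chloro group leaves the carbon-only ring where it was, with a 1.2-fold higher number from compound 2 to compound 4 (0.08 log units; within the scatter) and so no difference beyond the scatter. Across these four compounds the ring on the oxygen separates two levels: the pyridinyl ethers stand apart from both carbon-only rings, with a 4.2-fold lower number from compound 3 to compound 4 (0.62 log units; beyond the scatter) and a 4.1-fold lower number from compound 1 to compound 4 (0.62 log units; beyond the scatter) as the steps down. No measured evidence accounts for this split.

Still open, on these data alone, is whether an amine or a methoxy group on the carbon-only ring would move the number. The effect of a chloro group on the pyridin-2-yl ring is equally unknown.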